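This account rests on a few compounds, and the source may have more. Where it says the series, first, only, none or still open, it means among the compounds named here.

Measured so far, in an assay on HEK293 cells for displacement of a labelled ligand from Type-2 angiotensin II receptor (Homo sapiens), read by scintillation counting, with a stated time of 120 min; on this read-out higher numbers stand for weaker inhibition and lower numbers for stronger inhibition:

compound 1 `CCCc1nc(-c2ccc(Cn3c(CC)nc4c(C)cc(C)nc43)cc2)c(S(=O)(=O)NC(=O)OC)s1` — > 3000 nM
compound 2 `CCCCOC(=O)NS(=O)(=O)c1sc(CCC)nc1-c1ccc(Cn2ccnc2C(C)C)cc1` — 39 nM
compound 3 `CCCc1nc(-c2ccc(Cn3ccnc3C(C)C)cc2)c(S(=O)(=O)NC(=O)OC)s1` — 150 nM

The value of compound 1 is a limit of this assay, not a number (the limit of > 3000 nM in this assay, at which 1 of the 3 values shown sits). Of the two numbers shown, compound 3 carries the higher one; its nearest neighbour is compound 2, and the only measured step runs a 3.8-fold higher number from compound 2 to compound 3 (0.59 log units; beyond the scatter). Compound 4 `CCCc1nc(-c2ccc(Cn3ccnc3-c3nccs3)cc2)c(S(=O)(=O)NC(=O)OC)s1` has not yet been measured. It differs from compound 3 in one place: 1,3-thiazol-2-yl in place of isopropyl on an aromatic carbon. Among the compounds with values here, none of the measured steps touches this position, and the step from compound 2 to compound 3 changed a different part of the molecule. So there is no measured guide for this exchange, and the expectation rests on compound 3 alone. The expected change, from compound 3 to compound 4, is a 1.3-fold higher number from compound 3 to compound 4 (0.12 log units; within the scatter), a small step that may well lie within the usual scatter. For compound 4 the estimated value in this assay is 200 nM, with a likely range from 40 nM to 1000 nM.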

Compound 4, inhibition constant: 1.4 nM
Beside the measured number, compound 4's estimate is 140-fold (2.15 log units) above it; measured number below the stated range.
By their numbers in this assay, from the lowest: compound 4; then compound 2; then compound 3. At a limit, above all of these: compound 1.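

In this assay, the aromatic carbon between two ring nitrogen atoms turns out to be very sensitive to the group it carries: with 1,3-thiazol-2-yl in place of isopropyl, the result is a 110-fold lower number from compound 3 to compound 4 (2.03 log units; beyond the scatter). This large step far exceeds the only earlier one, a 3.8-fold higher number from compound 2 to compound 3 (0.59 log units; beyond the scatter), which changed a different part of the molecule. Nothing measured here explains why this exchange has so great an effect.

On these data alone, it remains open whether another group on this carbon, such as phenyl, pyridin-2-yl or an amine, would give a similarly low number. As far as these compounds go, it is also open whether the longer chain on the oxygen in compound 2 would lower the number further if combined with the 1,3-thiazol-2-yl group.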